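Removing the Ethylsulfamoyl Group From Compound 3

This account rests on a few compounds, and the source may have more. Where it says the series, first, only, none or still open, it means among the compounds named here.

Three compounds have been measured in an assay on COS-7 cells for inhibition of patatin-like phospholipase domain-containing protein 2 (Mus musculus), tested at 200 uM; on this read-out lower numbers stand for less inhibition and higher numbers for more inhibition at the one concentration tested (going by the name of the read-out):

Compound 1, `CCOC(=O)c1ccc(-c2ccc(OCC)cc2)o1`, gives 93%.
Compound 2, `CCOC(=O)c1ccc(-c2ccc(OCC)cc2)[nH]1`, gives 44%.
Compound 3, `CCNS(=O)(=O)c1cccc(-c2ccc(OCC)cc2)c1`, gives 46%.

Compound 3 has the second highest of these three readings. Its value and that of compound 2 lie within the scatter of each other, so no order between them can be claimed. Compound 1 stands well above compound 3, and that gap is beyond the scatter.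

The next compound, compound 4, `CCOc1ccc(-c2ccccc2)cc1`, is derived from compound 3 by a single change: hydrogen in place of ethylsulfamoyl on an aromatic carbon. The group that leaves carries the only hydrogen-bond donor and acceptors outside the shared core; what remains is the shared core with the ethoxy chain alone.

For the measured compounds named here, no measured pair in this set shows what such a removal does, so the expectation rests on the change itself. In this assay the step is expected to go downward, beyond the scatter, with compound 4 inhibiting less than compound 3. The expected step is a number 24 percentage points lower from compound 3 to compound 4 (beyond the scatter). Compound 4 is therefore estimated at 22%, within a range from 5% to 45%.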

Compound 4, a percentage reported as inhibition, at one concentration (the size of the read-out at that concentration, not a potency): 35%
Estimate against measurement, compound 4: 13 percentage points below, within the range that was stated.
By their numbers in this assay, from the lowest: compounds 4, 2 and 3 (each within the scatter of the next, the first and the last beyond it); then compound 1.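

For the compounds shown here, removing ethylsulfamoyl gives the first single change that can be read in this assay, with a number 11 percentage points lower from compound 3 to compound 4 (beyond the scatter), a modest step. The whole group, with its hydrogen-bond donor and acceptors, can therefore leave this aromatic carbon at the cost of only a modest part of the reading. Even with the ethoxy chain alone on the shared core, compound 4 gives 35% at the one concentration tested, so inhibition at this concentration does not depend on ethylsulfamoyl being present. No evidence at hand explains why the reading drops or why the drop has this size.

The compounds shown leave open whether an amine or a carboxylic acid on this same aromatic carbon would raise the reading above that of the bare core, and whether a longer chain in place of the ethyl in ethylsulfamoyl would change it. Going by these compounds alone, they also leave open how much the remaining ethoxy chain contributes, since no pair here shows it replaced by a methoxy group or by hydrogen.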